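The source may hold more compounds than are shown below. What is called first, only, known or untested is meant among the compounds shown, and "the series" means these compounds.

Of the compounds shown here, two sharing one core have been tested so far in a functional assay on KB cells (Homo sapiens) for inhibition, read by sulforhodamine B assay, with a stated time of 72 h; on this read-out higher numbers stand for weaker inhibition of growth and lower numbers for stronger inhibition of growth. Compound 1 (`CNC(=O)CCc1ccncc1-c1ccc2ccccc2c1`) gives > 10000 nM, which is a limit of the assay and not a number. Compound 2 (`O=C(/C=C/c1ccncc1-c1ccc2ccccc2c1)N1CCOCC1`) gives > 10000 nM, which is likewise a limit. The evidence so far is therefore (the limit of > 10000 nM in this assay, at which 2 of the 2 values shown sit), and compound 2 has no measured number of its own. The next compound is compound 3 (`NC(=O)/C=C/c1ccncc1-c1ccc2ccccc2c1`), not yet measured in this assay. It carries amino in place of morpholin-4-yl on a carbonyl carbon. Within the data shown here, no measured step is available as a guide, so no step beyond the scatter is expected in either direction, and the expected size is a step that the limit leaves unreadable from compound 2 to compound 3. The estimate for compound 3 is 12000 nM, with an expected range from 4000 nM to 30000 nM.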

Compound 3, concentration for 50% growth inhibition: > 10000 nM
Compound 3: only a limit was reported; the forecaster's own chance of this, stated with the estimate: 75%; the middle value lies beyond the limit too.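

Among these compounds, compound 3 gives > 10000 nM as a limit of the assay and not a number, so no step from compound 1 or compound 2 to compound 3 can be read. The compounds shown leave open how far any of them inhibits the growth of these cells, and whether amino and morpholin-4-yl on a carbonyl carbon differ at all.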